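Urea to Amide on the Anilide Carbonyl

The source may hold more compounds than are shown below. What is called first, only, known or untested is meant among the compounds shown, and "the series" means these compounds.

Measured so far in a functional assay on UO-31 cells (Homo sapiens) for inhibition, read by sulforhodamine B assay, with a stated time of 48 h; a lower number here means a stronger inhibitor of growth, a higher number a weaker inhibitor of growth:
compound 1 `COc1cc(-c2nn(-c3cccc(NC(=O)Nc4ccc(Cl)c(Cl)c4)c3)cc2-c2ccncc2)ccc1Cl` gives 4980 nM
compound 2 `COc1cc(-c2nn(-c3cccc(NC(=O)Nc4cccc(C(F)(F)F)c4)c3)cc2-c2ccncc2)ccc1Cl` gives 3210 nM

For the measured compounds named here, compound 2 has the lower of the two numbers, but the only measured step, a 1.6-fold lower number from compound 1 to compound 2 (0.19 log units; within the scatter), is within the scatter, so the two compounds cannot be ranked in this assay. Compound 3 `COc1cc(-c2nn(-c3cccc(NC(=O)c4ccc(Cl)c(C(F)(F)F)c4)c3)cc2-c2ccncc2)ccc1Cl` follows from compound 2 by a different kind of change: 4-chloro-3-(trifluoromethyl)phenyl in place of (3-(trifluoromethyl)phenyl)amino on a carbonyl carbon. Going by the values given here, the single measured step concerns the aryl group on the amide-type nitrogen and leaves the carbonyl and its amide-type nitrogen in place, so it bears on the present change only in showing that the region tolerates a swap of aryl substituents without a step beyond the scatter. Among the compounds with values here, no measured step addresses the loss of the amino link itself. Compound 3 is therefore expected near compound 2 in this assay, at 3500 nM with a range of 1100 nM to 11000 nM, a step of a 1.1-fold higher number from compound 2 to compound 3 (0.04 log units; within the scatter), with wide uncertainty.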

Compound 3, concentration for total growth inhibition: > 32500 nM
Compound 3: no number, only a limit (the forecaster's own chance of this, stated with the estimate: 5%); middle value at least 9.2-fold (0.96 log units) away from the limit.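

In this assay, the aryl swap on the amide-type nitrogen had stayed within the scatter, whereas the change on the carbonyl carbon gives an at least 10-fold higher number from compound 2 to compound 3 (1.00 log units; beyond the scatter) and an at least 6.5-fold higher number from compound 1 to compound 3 (0.81 log units; beyond the scatter). The result for compound 3 is a limit and not a number: the limit of > 32500 nM in this assay, at which 1 of the 3 values shown sits. So among these compounds the carbonyl position tolerates exchange of the aryl substituents while its amino link is kept, but compound 3, which lacks that link, is the weaker inhibitor of growth.

The change removes the amino nitrogen with its hydrogen-bond donor and also brings in a chlorine, and the compounds shown do not separate these two differences. Also open, from the compounds shown here alone, is whether 4-chloro-3-(trifluoromethyl)phenylamino on the carbonyl carbon, or a methylene link in place of the amino nitrogen, would give a number like that of compound 2.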